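Bromo in place of chloro at an assay limit

A few compounds are considered here, and "the series" means these few. Any claim that something is new, unique, unknown or untested is made for them only; others in the source may bear on it.

In a functional assay on K562 cells (Homo sapiens) for inhibition (on this read-out lower numbers stand for stronger inhibition and higher numbers for weaker inhibition), compound 1 `CCOc1ccc(Br)cc1-c1cc(Nc2ccc(B(O)O)cc2)nc(N)n1` gives 200 nM as its measured value. Compound 2 `CCOc1ccc(Cl)cc1-c1cc(Nc2ccc(Cl)cc2)nc(N)n1` reads < 12 nM as its result, which is a limit of the assay and not a number. Going by the values given here, compound 3 `CCOc1ccc(Br)cc1-c1cc(Nc2ccc(Cl)cc2)nc(N)n1` has not yet been measured and carries bromo in place of chloro on an aromatic carbon, para to an ethoxy group bromo in place of chloro on an aromatic carbon as its only difference from compound 2. Among the compounds with values here, no measured pair shows this change alone. The estimated step that the limit leaves unreadable from compound 2 to compound 3 is expected to stay within the usual scatter, in neither direction. Compound 3 is thus expected near 8 nM with 3 nM to 20 nM as its estimated range.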

Compound 3, half-maximal inhibitory concentration: 50 nM
Compound 3: middle estimate off by 6.3-fold (0.80 log units), on the low side, outside the stated range (above it).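

In this assay, this aromatic carbon, para to an ethoxy group, is sensitive to which halogen it carries: bromo in place of chloro gives an at least 4.1-fold higher number from compound 2 to compound 3 (0.61 log units; beyond the scatter). With bromo held constant, changing the other end of the molecule also matters, as one chlorine atom in place of the group of 3 heavy atoms gives a 4.0-fold lower number from compound 1 to compound 3 (0.60 log units; beyond the scatter). Compound 2 gives < 12 nM, which is a limit of the assay and not a number, so the first step has only a minimum size: the limit of < 12 nM in this assay, at which 1 of the 3 values shown sits.

The compounds shown do not reveal why bromo and chloro differ here. Going by these compounds, what a fluoro, a methyl or an amine would do at this same carbon also remains open.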